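A few compounds are considered here, and "the series" means these few. Any claim that something is new, unique, unknown or untested is made for them only; others in the source may bear on it.

Three compounds share one core and differ only in the group on an amine nitrogen of the piperazine-like ring. Compound 1 `Nc1ccccc1NC(=O)c1ccc(CSC(=S)N2CCN(c3cccnc3)CC2)cc1` carries pyridin-3-yl there and in a functional assay on A-375 cells (Homo sapiens) for antiproliferative activity, read by CCK-8 assay, with a stated time of 72 h, tested at 2 uM (on this read-out higher numbers stand for a stronger effect at the one concentration tested and lower numbers for a weaker effect), compound 1 gives 40.5%. Compound 2 `Nc1ccccc1NC(=O)c1ccc(CSC(=S)N2CCN(Cc3ccncc3)CC2)cc1` carries (pyridin-4-yl)methyl, and in this assay compound 2 gives 33.1%; the change a number 7.4 percentage points lower from compound 1 to compound 2 (within the scatter) is within the scatter. Compound 3 `Nc1ccccc1NC(=O)c1ccc(CSC(=S)N2CCN(c3ccccc3F)CC2)cc1` carries 2-fluorophenyl and in this assay compound 3 gives 18.7%, the lowest of the three numbers, as the steps of a number 21.8 percentage points lower from compound 1 to compound 3 (beyond the scatter) and a number 14.4 percentage points lower from compound 2 to compound 3 (beyond the scatter) show.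

Compound 4 `Nc1ccccc1NC(=O)c1ccc(CSC(=S)N2CCN(c3cnccn3)CC2)cc1` differs from compound 3 in one place: pyrazin-2-yl in place of 2-fluorophenyl on an amine nitrogen in a ring. Both steps that lead down to compound 3 swapped a nitrogen-containing six-membered aromatic ring for one of carbon only; the new group brings a nitrogen-containing aromatic ring back, so a rise of modest size is expected, roughly undoing the step from compound 1 to compound 3. Compound 4 is therefore expected to give 35% in this assay, with a range from 20% to 50%, which means an expected step of a number 16.3 percentage points higher from compound 3 to compound 4 (beyond the scatter).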

Compound 4, a percentage reported as inhibition, at one concentration (the size of the read-out at that concentration, not a potency): 29.1%
Estimate against measurement, compound 4: 5.9 percentage points above; the range from low to high includes it.
By their numbers in this assay, from the lowest: compound 3; then compounds 4, 2 and 1 (each within the scatter of the next, the first and the last beyond it).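

In this assay the swap to pyrazin-2-yl gives a step of a number 10.4 percentage points higher from compound 3 to compound 4 (beyond the scatter) and so places a second ring containing nitrogen above 2-fluorophenyl on this amine nitrogen. Nitrogen in the ring is not enough to match pyridin-3-yl, however, as the step of a number 11.4 percentage points lower from compound 1 to compound 4 (beyond the scatter) shows. The step of a number 4 percentage points lower from compound 2 to compound 4 (within the scatter) leaves pyrazin-2-yl and (pyridin-4-yl)methyl unseparated, and nothing available here explains any of these differences.

Going by these compounds, it remains open whether an aromatic ring is needed at this place at all, which a plain methyl or an acetyl group on the same nitrogen would test. Also open, on these data alone, is whether these differences at a single concentration would hold as differences in potency.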